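The source may hold more compounds than are shown below. What is called first, only, known or untested is meant among the compounds shown, and "the series" means these compounds.

Measured so far in a functional assay on HCT-15 cells (Homo sapiens) for inhibition, read by sulforhodamine B assay, with a stated time of 72 h; on this read-out higher numbers stand for weaker inhibition and lower numbers for stronger inhibition:
- compound 1 `Cc1cc(=O)c2ccc(O)c(CN(Cc3ccccc3)Cc3ccccc3)c2o1`: 11.3 ug/mL
- compound 2 `CCN(Cc1ccc(OC)cc1)Cc1c(O)ccc2c(=O)cc(C)oc12`: 22.5 ug/mL
- compound 3 `COc1ccc(CN(Cc2ccc([N+](=O)[O-])cc2)Cc2c(O)ccc3c(=O)cc(C)oc23)cc1`: 28.6 ug/mL

Compound 3, at 28.6 ug/mL, sits with compound 2 at the upper end of these numbers, the two being level within the scatter. Compound 1 lies lower than compound 3, and that gap goes beyond the scatter.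

The next compound is compound 4 `COc1ccc(CN(Cc2ccc(OC)cc2)Cc2c(O)ccc3c(=O)cc(C)oc23)cc1`. The change from compound 3 is methoxy in place of nitro on an aromatic carbon. In words, this is methoxy in place of nitro on an aromatic carbon, para to a large group, turning 4-nitrobenzyl into 4-methoxybenzyl.

For the measured compounds named here, only one measured step bears on this directly: a 1.3-fold higher number from compound 2 to compound 3 (0.10 log units; within the scatter). It brings in the 4-nitrophenyl that now leaves, and it stays within the scatter. Going by the values given here, no measured step shows methoxy and nitro exchanged on the same carbon, so the evidence is indirect. The value of compound 1, 11.3 ug/mL, shows that a lower number is reachable with two benzyl groups on the amine nitrogen, which allows a small lean downward.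

The expected change is a 1.4-fold lower number from compound 3 to compound 4 (0.13 log units; within the scatter), so no step beyond the scatter is expected in this assay.

The estimated value for compound 4 is 21 ug/mL, with an expected range from 11 ug/mL to 40 ug/mL.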

Compound 4, half-maximal inhibitory concentration: 53.7 ug/mL
Beside the measured number, compound 4's estimate is 2.6-fold (0.41 log units) below it; the measured number lies above the stated range.
By their numbers in this assay, from the lowest: compounds 1, 2, 3 and 4 (each within the scatter of the next, the first and the last beyond it).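

In this assay, for the compounds shown here, the first measured exchange on this aromatic carbon, para to a large group, gives a 1.9-fold higher number from compound 3 to compound 4 (0.27 log units; within the scatter); 4-nitrobenzyl and 4-methoxybenzyl therefore cannot be told apart here when the other substituent on the amine nitrogen is also a 4-methoxybenzyl. The series also gains its first single-place step beyond the scatter, a 2.4-fold higher number from compound 2 to compound 4 (0.38 log units; beyond the scatter), a modest step that places 4-methoxyphenyl on the saturated chain carbon bound to the amine nitrogen, whereas 4-nitrophenyl at that same carbon gave a 1.3-fold higher number from compound 2 to compound 3 (0.10 log units; within the scatter), so the replacement of methyl at this carbon can register on this read-out, with the size of the effect resting on only these two examples. No data available here bear on what lies behind these numbers.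

As far as these compounds go, whether a carboxylic acid or an amine on the same aromatic carbon would give a number outside the scatter of compound 3 and compound 4 remains open. Also open, from the compounds shown here alone, is how a longer chain, such as propyl or butyl, would read in place of the ethyl group of compound 2.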